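A few compounds are considered here, and "the series" means these few. Any claim that something is new, unique, unknown or untested is made for them only; others in the source may bear on it.

Notes on an ADME assay on microsomes from liver (Mus musculus, strain ICR) for metabolic stability, read by LC-MS, using NADPH, with a stated time of 60 min, tested at 0.1 uM (on this read-out higher numbers stand for a more stable compound and lower numbers for a less stable compound), for this series: compound 1 `CC#CCn1c(N2CCC[C@@H](N)C2)cc(=O)n(Cc2ccc(Br)c(C(=O)OC)c2)c1=O` gives 38.1% and compound 2 `CC#CCn1c(N2CCC[C@@H](N)C2)cc(=O)n(Cc2ccc(F)c(C(=O)O)c2)c1=O` gives 37.5% in the same read-out, two values within the usual scatter of each other. Compound 2 therefore stands together with compound 1, and no order can be read between them. Compound 3 `CC#CCn1c(N2CCC[C@@H](N)C2)cc(=O)n(Cc2ccc(Br)c(C(=O)O)c2)c1=O` has not yet been measured. The change from compound 2 (bromo in place of fluoro on an aromatic carbon) is bromo in place of fluoro on an aromatic carbon, ortho to a carboxy group and para to a large group. Going by the values given here, no measured pair shows this exchange, so the data give no direct size for it. Taking compound 2 at 37.5% as the starting point, no step beyond the scatter is expected in either direction. The estimated a number 0.5 percentage points higher from compound 2 to compound 3 (within the scatter) stays within the scatter. For compound 3 the estimated value is 38% with an expected range of 26% to 50% for a single measurement.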

Compound 3, percent of the compound remaining: 58.2%
Compound 3: the middle estimate sits 20.2 percentage points below what was measured; the measured number lies above the stated range.
By their numbers in this assay, from the lowest: compounds 2 and 1 (each within the scatter of the next); then compound 3.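

In this assay, bromo in place of fluoro on the aromatic carbon, ortho to a carboxy group and para to a large group, goes with a number 20.7 percentage points higher from compound 2 to compound 3 (beyond the scatter), the first sign in this series that the halogen at this position matters to the read-out. With bromo held in place, hydrogen in place of methyl on an oxygen next to a carbonyl group goes with a number 20.1 percentage points higher from compound 1 to compound 3 (beyond the scatter), so within these compounds the higher number appears only where bromo and the carboxy group occur together. Going by these compounds alone, nothing measured so far gives a reason for either step.

Going by these compounds, whether chloro or a methoxy group at this position would behave like bromo or like fluoro remains open. Also open, on these data alone, is the size of the methyl-to-hydrogen step with fluoro on the ring.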